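Methoxy to trifluoromethoxy on a shared phenoxy ring

The source may report more compounds than this note shows. Statements on the series, on what has been measured and on what is new or still open speak of the compounds shown alone.

Three analogues built on one shared core have been measured in a functional assay on HCT-116 cells (Homo sapiens) for antiproliferative activity, read by MTT assay, with a stated time of 72 h; on this read-out higher numbers stand for weaker inhibition and lower numbers for stronger inhibition. Compound 1 `Cc1nn(C)c(Oc2ccc(OC(F)(F)F)cc2)c1/C=N\OCc1c(Cl)c(-c2ccc(F)cc2)nn1C` gives 2310 nM, compound 2 `Cc1nn(C)c(Oc2ccc(F)cc2)c1/C=N\OCc1c(Cl)c(-c2ccc(Cl)cc2)nn1C` gives 7250 nM, and compound 3 `COc1ccc(Oc2c(/C=N\OCc3c(Cl)c(-c4ccc(Cl)cc4)nn3C)c(C)nn2C)cc1` gives 1260 nM. Compound 3 sits at the low end of these three numbers: compound 1 lies within the scatter of it, whereas the step of a 5.8-fold lower number from compound 2 to compound 3 (0.76 log units; beyond the scatter) stands beyond the scatter. Compound 4 `Cc1nn(C)c(Oc2ccc(OC(F)(F)F)cc2)c1/C=N\OCc1c(Cl)c(-c2ccc(Cl)cc2)nn1C` is compound 3 with trifluoromethyl in place of methyl on an oxygen on an aromatic ring. Going by the values given here, no measured step covers this exact change. Among the compounds with values here, the one step in hand, a 5.8-fold lower number from compound 2 to compound 3 (0.76 log units; beyond the scatter), concerns a different substituent on the same ring, so its size cannot be carried over directly. Compound 1 already bears the trifluoromethoxy group, differing from compound 4 only by fluorine rather than chlorine elsewhere, and compound 1 gives 2310 nM. Compound 4 is therefore expected to give about 2000 nM, within a range of 800 nM to 5000 nM. The resulting step of a 1.6-fold higher number from compound 3 to compound 4 (0.20 log units; within the scatter) is expected to be small, in the direction of a slightly higher number.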

Compound 4, half-maximal inhibitory concentration: 3020 nM
The estimate for compound 4 lay 1.5-fold (0.18 log units) below the measured number; the range from low to high includes it.
By their numbers in this assay, from the lowest: compounds 3, 1 and 4 (each within the scatter of the next, the first and the last beyond it); then compound 2.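

On the shared core with chloro held elsewhere, this position now separates three groups in this assay: trifluoromethoxy in place of methoxy weakens inhibition (a 2.4-fold higher number from compound 3 to compound 4 (0.38 log units; beyond the scatter)), yet it still improves on fluoro (a 2.4-fold lower number from compound 2 to compound 4 (0.38 log units; beyond the scatter)), so trifluoromethoxy lies between methoxy and fluoro, with each step beyond the scatter. Within the trifluoromethoxy pair, chloro in place of fluoro on the other aromatic carbon makes no distinguishable difference (a 1.3-fold higher number from compound 1 to compound 4 (0.12 log units; within the scatter)). Nothing measured here accounts for this order of the three groups.

From the compounds shown here alone, whether methoxy keeps its advantage over trifluoromethoxy with fluoro in place of chloro on that other aromatic carbon remains open. So does the outcome at this position with an amine, a carboxylic acid or a longer chain such as ethoxy.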